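From pyridin-4-yl to 4-cyanophenyl on the shared core

The source may report more compounds than this note shows. Statements on the series, on what has been measured and on what is new or still open speak of the compounds shown alone.

- Compound 1 `COc1ccc(-c2cccc3c2N(S(=O)(=O)c2ccc(OC)cc2)CC3)cc1`: 352 nM
- Compound 2 `COc1ccc(S(=O)(=O)N2CCc3cccc(-c4ccncc4)c32)cc1`: 106 nM

In a functional assay on KB-VIN10 cells (Homo sapiens) for inhibition, with a stated time of 72 h (a higher number here means a weaker inhibitor, a lower number a stronger inhibitor), compound 2 holds the lower of the two numbers, at 106 nM. Compound 3 `COc1ccc(S(=O)(=O)N2CCc3cccc(-c4ccc(C#N)cc4)c32)cc1` carries 4-cyanophenyl in place of pyridin-4-yl on an aromatic carbon. Going by the values given here, one measured step bears on this change: a 3.3-fold lower number from compound 1 to compound 2 (0.52 log units; beyond the scatter), a modest step beyond the scatter, with pyridin-4-yl replacing 4-methoxyphenyl. Compound 3 again carries an aromatic ring of carbon only, as compound 1 does at 352 nM. On that single comparison, a modest move to a higher number is expected: a 1.9-fold higher number from compound 2 to compound 3 (0.28 log units; within the scatter). For compound 3 the estimated value is 200 nM, with an expected range of 70 nM to 550 nM.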

Compound 3, half-maximal inhibitory concentration: 29.2 nM
Compound 3: middle estimate off by 6.8-fold (0.84 log units), on the high side; the whole stated range lies above it.
By their numbers in this assay, from the lowest: compound 3; then compound 2; then compound 1.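

In this assay, a ring of carbon only at this position need not give the higher number: 4-cyanophenyl in place of pyridin-4-yl gives a 3.6-fold lower number from compound 2 to compound 3 (0.56 log units; beyond the scatter). On that same kind of ring, cyano in place of methoxy gives a 12-fold lower number from compound 1 to compound 3 (1.08 log units; beyond the scatter) and so the group the ring carries weighs heavily here. Nothing measured here explains either step. The compounds shown leave open how a carboxylic acid, a primary amide or a chlorine atom would compare with cyano on that ring.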